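From Propyl to Ethoxy in the Chain of Compound 2

The source may hold more compounds than are shown below. What is called first, only, known or untested is meant among the compounds shown, and "the series" means these compounds.

In a functional assay on A549 cells (Homo sapiens) for inhibition, read by sulforhodamine B assay, with a stated time of 72 h (a lower number here means a stronger inhibitor, a higher number a weaker inhibitor), compound 1 `COc1cc2c(Nc3cccc(Br)c3)ncnc2cc1OCCCn1ccnc1[N+](=O)[O-]` gives 13500 nM and compound 2 `COc1cc2c(Nc3cccc(Br)c3)ncnc2cc1OCCCCCn1ccnc1[N+](=O)[O-]` gives 8780 nM. Within the data shown here, these two values lie within the scatter of each other, so compound 2 stands level with the only other compound measured so far.

Compound 3 `COc1cc2c(Nc3cccc(Br)c3)ncnc2cc1OCCOCCn1ccnc1[N+](=O)[O-]` keeps the shared core of compound 2 and alters only the chain: 2-(2-nitro-1H-imidazol-1-yl)ethoxy in place of 3-(2-nitro-1H-imidazol-1-yl)propyl on a saturated chain carbon, two bonds along the chain from an oxygen on an aromatic ring. Here 2-(2-nitro-1H-imidazol-1-yl)ethoxy comes in place of 3-(2-nitro-1H-imidazol-1-yl)propyl on a saturated chain carbon, two bonds along the chain from an oxygen on an aromatic ring.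

Among the measured compounds shown here, only one measured step bears on this change, a 1.5-fold lower number from compound 1 to compound 2 (0.19 log units; within the scatter), and it stayed within the scatter. For the measured compounds named here, that step lengthens the chain and brings in no new oxygen, so it is a loose guide, and no measured pair tests this exact swap. No step beyond the scatter is therefore expected in this assay, in either direction. The estimated step is a 1.1-fold higher number from compound 2 to compound 3 (0.06 log units; within the scatter). Compound 3 is expected to give about 10000 nM, with an estimated range of 4000 nM to 25000 nM.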

Compound 3, half-maximal inhibitory concentration: 13000 nM
For compound 3 the middle estimate is 1.3-fold (0.11 log units) below the measured one; measured number inside the range.
By their numbers in this assay, from the lowest: compounds 2, 3 and 1 (each within the scatter of the next).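

In this assay, one oxygen in place of one carbon in the chain gives a 1.5-fold higher number from compound 2 to compound 3 (0.17 log units; within the scatter), so at this place 2-(2-nitro-1H-imidazol-1-yl)ethoxy and 3-(2-nitro-1H-imidazol-1-yl)propyl cannot be told apart by this read-out. The comparison with the shortest chain of the set, a 1.0-fold lower number from compound 1 to compound 3 (0.02 log units; within the scatter), also stays within the scatter, which means that all three compounds now stand level, with or without the added chain oxygen and across the chains shown. Among these compounds, nothing presented here gives a measured reason for this flat result, and the numbers alone show only that these chain changes produced no readable difference in this assay.

As far as these compounds go, all three compounds carry the same 2-nitro-1H-imidazol-1-yl end on the same shared core, so it remains open whether anything at this end of the chain can move the number beyond the scatter. An amine in place of 2-nitro-1H-imidazol-1-yl, or a much longer chain, would test that question more sharply than the small swap seen here.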